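Swapping methylcarbamoyl for 1,2-oxazol-4-yl in compound 3

This account rests on a few compounds, and the source may have more. Where it says the series, first, only, none or still open, it means among the compounds named here.

Compound 1 `Nc1nccc(COc2ccc3nc(N[C@@H]4CCCC[C@H]4O)sc3c2)c1Cl` gives 68 mL/min/kg
Compound 2 `COc1cc(OCc2ccnc(N)c2Cl)cc2sc(N[C@@H]3CCCC[C@H]3O)nc12` gives 99 mL/min/kg
Compound 3 `CNC(=O)Nc1nccc(COc2cc(OC)c3nc(N[C@H]4CCCC[C@@H]4O)sc3c2)n1` gives 19 mL/min/kg

In an ADME assay on microsomes from liver (Rattus norvegicus, strain Sprague-Dawley) for pharmacokinetics, read by LC-MS, using NADPH, with a stated time of 45 min, tested at 1 uM (a higher number here means faster removal of the compound, a lower number slower removal), compound 3 stands lowest of the three, beyond the scatter from both others. Compound 4 `COc1cc(OCc2ccnc(Nc3cnoc3)n2)cc2sc(N[C@H]3CCCC[C@@H]3O)nc12` is still unmeasured. The change 1,2-oxazol-4-yl in place of methylcarbamoyl on a nitrogen on an aromatic ring puts 1,2-oxazol-4-yl in place of methylcarbamoyl on a nitrogen on an aromatic ring. Among the measured compounds shown here, the one measured step of a 1.5-fold higher number from compound 1 to compound 2 (0.16 log units; within the scatter) is a methoxy in place of hydrogen on an aromatic carbon, lies within the scatter and does not cover this change. Compound 1 at 68 mL/min/kg and compound 2 at 99 mL/min/kg lack methylcarbamoyl but also differ from compound 3 in other places, so only a moderate rise is expected. The estimated step is a 2.1-fold higher number from compound 3 to compound 4 (0.32 log units; beyond the scatter) in the upward direction. The estimate for compound 4 is 40 mL/min/kg and the expected range runs from 18 mL/min/kg to 85 mL/min/kg at its two ends.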

Compound 4, clearance: 87 mL/min/kg
Beside the measured number, compound 4's estimate is 2.2-fold (0.34 log units) below it; measured number outside the range, above it.
By their numbers in this assay, from the lowest: compound 3; then compounds 1, 4 and 2 (each within the scatter of the next).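

In this assay, putting 1,2-oxazol-4-yl in place of methylcarbamoyl on a nitrogen on an aromatic ring gives a 4.6-fold higher number from compound 3 to compound 4 (0.66 log units; beyond the scatter), so the group on this nitrogen alone moves the clearance beyond the scatter. The earlier step, on an aromatic carbon, stayed within the scatter and showed nothing about this position. Nothing measured here accounts for the rise. From the compounds shown here alone, whether ethylcarbamoyl, acetyl or a plain amine at this place would stand nearer compound 3 or compound 4 remains open.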